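The compounds below may be only part of what the source reports. "The series", "measured", "known", "first", "only" and "open" are said of these compounds alone.

In a functional assay on CNE-2 cells (Homo sapiens) for antiproliferative activity, read by sulforhodamine B assay, with a stated time of 48 h (a lower number here means a stronger inhibitor, a higher number a weaker inhibitor), three compounds built on a shared core have been measured so far. Compound 1 `COc1cc(C=C(C(=O)/C=C/c2cccc(OC)c2OC)C(=O)/C=C/c2cccc(OC)c2OC)ccc1O` gives 280 nM, compound 2 `COc1ccc(C=C(C(=O)/C=C/c2cccc(OC)c2OC)C(=O)/C=C/c2cccc(OC)c2OC)cc1OC` gives 280 nM, and compound 3 `COc1cccc(/C=C/C(=O)C(=Cc2ccc(O)c(F)c2)C(=O)/C=C/c2cccc(OC)c2OC)c1OC` gives 260 nM. These three numbers lie within the scatter of one another, so compound 3 stands level with the other two.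

The next compound, compound 4 `COc1ccc(C=C(C(=O)/C=C/c2cccc(OC)c2OC)C(=O)/C=C/c2cccc(OC)c2OC)cc1O`, differs from compound 3 in one group on a double-bonded chain carbon bound to a double-bonded chain carbon: 3-hydroxy-4-methoxyphenyl in place of 3-fluoro-4-hydroxyphenyl on a double-bonded chain carbon bound to a double-bonded chain carbon.

Going by the values given here, three measured steps bear on this change, as each alters the same group: no change at the digits printed from compound 1 to compound 2 (within the scatter), a 1.1-fold lower number from compound 1 to compound 3 (0.03 log units; within the scatter) and a 1.1-fold lower number from compound 2 to compound 3 (0.03 log units; within the scatter). Among these three compounds, changing this group has not moved the number beyond the scatter. No clear direction can be drawn from them, so no real shift is expected in this assay for the new group.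

The expected result is a 1.0-fold higher number from compound 3 to compound 4 (0.02 log units; within the scatter), a step within the scatter. The estimate for compound 4 is 270 nM, with an expected range of 150 nM to 480 nM.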

Compound 4, half-maximal inhibitory concentration: 220 nM
Beside the measured number, compound 4's estimate is 1.2-fold (0.09 log units) above it; low and high end bracket the measured number.
By their numbers in this assay, from the lowest: compounds 4, 3, 1 and 2 (each within the scatter of the next).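

In this assay, replacing 3-fluoro-4-hydroxyphenyl with 3-hydroxy-4-methoxyphenyl gives a 1.2-fold lower number from compound 3 to compound 4 (0.07 log units; within the scatter), so a fourth group at this position reads level with the other three. Exchanging 4-hydroxy-3-methoxyphenyl for 3-hydroxy-4-methoxyphenyl gives a 1.3-fold lower number from compound 1 to compound 4 (0.10 log units; within the scatter), and removing one methyl from an oxygen gives a 1.3-fold lower number from compound 2 to compound 4 (0.10 log units; within the scatter), so among these four compounds neither the arrangement of hydroxy and methoxy groups on this ring nor that single methyl moves the number beyond the scatter. No available measurement explains why these groups read alike.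

Going by these compounds alone, every group at this position so far is a phenyl ring carrying only hydroxy, methoxy or fluoro, so the effect of an amine or a carboxylic acid on that ring remains open. On these data alone, all four compounds also share the rest of the core, so changes elsewhere remain untested here.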